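Bromo Substitution on a Pyrazoline Series Against Melanoma Cells

The compounds below may be only part of what the source reports. "The series", "measured", "known", "first", "only" and "open" are said of these compounds alone.

Measured compounds:
- compound 1, `COc1ccc(C2CC(c3ccc(Br)cc3)=NN2C(=O)c2ccc3c(c2)OCCO3)cc1`: 5680 nM
- compound 2, `O=C(C1COc2ccccc2O1)N1N=C(c2ccccc2)CC1c1ccc(F)cc1`: 3270 nM
- compound 3, `COc1ccc(C2CC(c3ccccc3)=NN2C(=O)c2ccc3c(c2)OCCO3)cc1`: 8370 nM

All three compounds were tested in a functional assay on WM 266-4 cells (Homo sapiens) for inhibition, read by MTT assay, with a stated time of 24 h; on this read-out lower numbers stand for stronger inhibition of growth and higher numbers for weaker inhibition of growth. In this assay compound 3 gives 8370 nM, and compound 1 gives 5680 nM. These two share one core and differ in a single place: bromo in place of hydrogen on an aromatic carbon. The step that this change made is a 1.5-fold lower number from compound 3 to compound 1 (0.17 log units; within the scatter), so the two numbers cannot be told apart with confidence.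

Compound 2 sits on a different core; how its core differs from that of compound 3 is not broken down here. In this assay compound 2 gives 3270 nM, which is within the scatter of compound 1 and beyond the scatter of compound 3.

Compound 4, `O=C(C1COc2ccccc2O1)N1N=C(c2ccc(Br)cc2)CC1c1ccc(F)cc1`, has not yet been measured. It stands to compound 2 as compound 1 stands to compound 3: the change is bromo in place of hydrogen on an aromatic carbon. The two place descriptions read the same word for word, so this is the same change made a second time, now on the other core.

Because the earlier step of a 1.5-fold lower number from compound 3 to compound 1 (0.17 log units; within the scatter) was small, the step from compound 2 to compound 4 is expected to be of similar size, about a 1.5-fold lower number from compound 2 to compound 4 (0.17 log units; within the scatter). Compound 4 is therefore expected to give roughly 2200 nM in this assay, with a likely range from 1000 nM to 5000 nM, resting on a single precedent from one pair of compounds.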

Compound 4, concentration for 50% growth inhibition: 5630 nM
For compound 4 the middle estimate is 2.6-fold (0.41 log units) below the measured one; measured number outside the range, above it.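

In this assay, putting bromo in place of hydrogen on the phenyl ring of compound 2 gives a 1.7-fold higher number from compound 2 to compound 4 (0.24 log units; within the scatter), so this pair, like the earlier one, shows no change that can be told apart from the ordinary spread of repeated measurements. On paper the two steps point in opposite directions, but that difference is too small to count as a real disagreement between the cores: the same change on two cores in this assay, a 1.5-fold lower number (0.17 log units; within the scatter) from compound 3 to compound 1 and a 1.7-fold higher number (0.24 log units; within the scatter) from compound 2 to compound 4, 2.5-fold (0.40 log units) apart, within the scatter of two such steps. For the compounds shown here, this shows that, on both cores, the swap from phenyl to 4-bromophenyl produced no clear shift in growth inhibition, and that the two results are consistent with each other; it does not show that the change has exactly the same effect on each core, or that bromo makes no difference on other cores, since the evidence is only two pairs of compounds in a single assay.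

The compounds shown leave open whether an amine or a carboxylic acid at this same place on the ring would move the number beyond the scatter. They also leave open whether the bromo step would stay this small on a core carrying a longer chain.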